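Removing a methoxy from the shared core: expectation for compound 4

The source may hold more compounds than are shown below. What is called first, only, known or untested is meant among the compounds shown, and "the series" means these compounds.

Measured so far:
- compound 1, `COc1ccc(-c2nc(SCC(=O)c3sc(-c4ccccc4)nc3C)[nH]c(=O)c2C#N)cc1`: 1.08%
- compound 2, `COc1ccc(-c2nc(C)c(C(=O)CSc3nc(-c4ccc(OC)cc4)c(C#N)c(=O)[nH]3)s2)cc1`: 11.5%
- compound 3, `COc1ccc(-c2nc(C)c(C(=O)CSc3nc(-c4ccc(Cl)c(Cl)c4)c(C#N)c(=O)[nH]3)s2)cc1`: 31.1%

In a functional assay on U-87MG ATCC cells for antiproliferative activity against U-87 MG (Homo sapiens), read by MTT assay, with a stated time of 48 h, tested at 100 uM (a lower number here means a stronger effect, a higher number a weaker effect of the compound at the concentration tested), compound 1 gives the lowest of the three numbers, which here means the strongest effect; the steps to compound 2 and compound 3 are both beyond the scatter. Compound 4, `Cc1nc(-c2ccccc2)sc1C(=O)CSc1nc(-c2ccccc2)c(C#N)c(=O)[nH]1`, has not yet been measured. It differs from compound 1 in one place: hydrogen in place of methoxy on an aromatic carbon.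

Among the compounds with values here, two measured steps bear on this change. Adding a methoxy on the other aromatic ring gave a number 10.4 percentage points higher from compound 1 to compound 2 (beyond the scatter), and swapping 4-methoxyphenyl for 3,4-dichlorophenyl gave a number 19.6 percentage points higher from compound 2 to compound 3 (beyond the scatter). Both are modest, and the first shows that gaining a methoxy made the number higher. The change from compound 1 to compound 4 goes the other way, a methoxy leaving, so if anything the number should stay low; compound 1 already sits close to the bottom of the scale, leaving little room to fall further.

The expected result for compound 4 is therefore 3%, within 0% to 15%, which means an estimated step of a number 1.9 percentage points higher from compound 1 to compound 4 (within the scatter), not beyond the scatter.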

Compound 4, a percentage reported as activity, at one concentration (the size of the read-out at that concentration, not a potency): 9.23%
Estimate against measurement, compound 4: 6.2 percentage points below; the range from low to high includes it.
By their numbers in this assay, from the lowest: compounds 1, 4 and 2 (each within the scatter of the next, the first and the last beyond it); then compound 3.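

In this assay, taking the methoxy off the ring where it sits para to a large group gives a number 8.2 percentage points higher from compound 1 to compound 4 (within the scatter), so a plain phenyl in place of 4-methoxyphenyl leaves compound 1 and compound 4 with no order between them, and this methoxy is not needed for a low number at this concentration. The earlier compounds shown here showed only that this position responds to a different swap, 3,4-dichlorophenyl for 4-methoxyphenyl, with a number 19.6 percentage points higher from compound 2 to compound 3 (beyond the scatter) on a core that also carries a second methoxy, and that adding a methoxy on the other aromatic ring gives a number 10.4 percentage points higher from compound 1 to compound 2 (beyond the scatter), so the same group counts differently at the two sites in these pairs. No measurement shown offers a reason for this tolerance of losing the methoxy.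

Going by these compounds, whether a hydroxyl, an amine or a carboxylic acid at this position would keep the number as low remains open. Also open, on these data alone, is whether a compound with a methoxy on the other aromatic ring alone would behave like compound 2, and how these compounds rank at lower concentrations, where a single reading at one concentration says nothing about potency.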